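Replacing methoxy on the aryl amide of compound 3

A few compounds are considered here, and "the series" means these few. Any claim that something is new, unique, unknown or untested is made for them only; others in the source may bear on it.

In an ADME assay on BaF3 cells (Mus musculus) for antiproliferative activity, read by CCK-8 assay, with a stated time of 72 h; a lower number here means a stronger inhibitor of growth, a higher number a weaker inhibitor of growth:
Compound 1 `Cc1cccc(NC(=O)CCSc2ccc3c(/C=C/c4ccccn4)n[nH]c3c2)c1`: > 10000 nM (a limit)
Compound 2 `Cc1ccc(NC(=O)CCSc2ccc3c(/C=C/c4ccccn4)n[nH]c3c2)cc1C(F)(F)F`: 530 nM
Compound 3 `COc1ccc(NC(=O)CCSc2ccc3c(/C=C/c4ccccn4)n[nH]c3c2)cc1C(F)(F)F`: > 10000 nM (a limit)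

Compound 3 gives only a limit, sitting at the limit of > 10000 nM in this assay, at which 2 of the 3 values shown sit. Compound 4 `CC1CCN(Cc2ccc(NC(=O)CCSc3ccc4c(/C=C/c5ccccn5)n[nH]c4c3)cc2C(F)(F)F)CC1` has (4-methylpiperidin-1-yl)methyl in place of methoxy on an aromatic carbon. On this same carbon, methoxy in place of methyl gave an at least 18-fold higher number from compound 2 to compound 3 (1.27 log units; beyond the scatter). Putting 4-methyl-3-(trifluoromethyl)phenyl in place of 3-methylphenyl gave an at least 18-fold lower number from compound 1 to compound 2 (1.27 log units; beyond the scatter). Going by these compounds, both steps are large, but the entering group itself is untested. A large move to a lower number in this assay is therefore expected, as the estimated at least 25-fold lower number from compound 3 to compound 4 (1.39 log units; beyond the scatter). For compound 4 the estimate is 400 nM, with an expected range from 50 nM to 4000 nM.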

Compound 4, concentration for 50% growth inhibition: 4170 nM
Beside the measured number, compound 4's estimate is 10-fold (1.02 log units) below it; measured number outside the range, above it.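

On this aromatic carbon, para to a large group, (4-methylpiperidin-1-yl)methyl gives a measured value where methoxy did not, with an at least 2.3-fold lower number from compound 3 to compound 4 (0.37 log units; beyond the scatter). Compound 3 gives only a limit, so that step is a bound and not a full size: the limit of > 10000 nM in this assay, at which 2 of the 4 values shown sit.

Even so, the larger group does not match methyl on the same carbon, with a 7.9-fold higher number from compound 2 to compound 4 (0.90 log units; beyond the scatter), so methyl remains the better of the three groups measured here.

Going by these compounds, it remains open whether a morpholin-4-ylmethyl or a dimethylaminomethyl group on this carbon would come closer to methyl. On these data alone, whether the methyl on the piperidine ring matters is also open.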